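The compounds below may be only part of what the source reports. "The series", "measured", "known", "first", "only" and "open" are said of these compounds alone.

Series notes. Going by the values given here, compound 1 `CCCCc1nc(C)c(CC(=O)N2CCC[C@H]2C(=O)OC)c(=O)n1Cc1ccc(-c2ccccc2-c2nnn[nH]2)cc1` gives 0.043 mg/kg in an in vivo functional assay on the whole organism for inhibition, with Rattus norvegicus as the target (on this read-out lower numbers stand for an effect already at smaller amounts and higher numbers for an effect only at larger amounts of compound), the second highest of the three numbers so far. Compound 2 `CCCCc1nc(C)c(CCC(=O)N2CCC[C@H]2C(=O)OC)c(=O)n1Cc1ccc(-c2ccccc2-c2nnn[nH]2)cc1` gives 0.063 mg/kg and compound 3 `CCCCc1nc(C)c(CC(=S)N(CC)CC)c(=O)n1Cc1ccc(-c2ccccc2-c2nnn[nH]2)cc1` gives 0.023 mg/kg. Among the compounds with values here, the steps run a 1.5-fold higher number from compound 1 to compound 2 (0.17 log units; within the scatter) and a 1.9-fold lower number from compound 1 to compound 3 (0.27 log units; within the scatter); only the step of a 2.7-fold lower number from compound 2 to compound 3 (0.44 log units; beyond the scatter) reaches beyond the scatter.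

The next compound is compound 4 `CCCCc1nc(C)c(CC(=S)N2CCCCCC2)c(=O)n1Cc1ccc(-c2ccccc2-c2nnn[nH]2)cc1`. Relative to compound 1 the change is a group of 9 heavy atoms (7 carbon, 1 nitrogen, 1 sulfur; one seven-membered non-aromatic ring with 1 hetero atom) in place of a group of 11 heavy atoms (7 carbon, 1 nitrogen, 3 oxygen; one five-membered non-aromatic ring with 1 hetero atom), on a saturated chain carbon bound to an aromatic carbon. The step that bears on it most closely is a 1.9-fold lower number from compound 1 to compound 3 (0.27 log units; within the scatter), where a thioamide likewise replaced the methoxycarbonyl-pyrrolidinyl carbonyl group at the same position; the difference there stayed within the scatter. Within the data shown here, compound 4 carries a seven-membered ring on the thioamide nitrogen in place of the two ethyl groups of compound 3, and nothing measured so far speaks to that part of the change.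

The expectation is therefore a step of about a 1.5-fold lower number from compound 1 to compound 4 (0.19 log units; within the scatter), toward a lower number but not clearly beyond the scatter, resting on a 1.9-fold lower number from compound 1 to compound 3 (0.27 log units; within the scatter). Compound 4 is estimated to give 0.028 mg/kg in this assay, with a range from 0.012 mg/kg to 0.065 mg/kg.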

Compound 4, dose for half-maximal effect: 0.034 mg/kg
Beside the measured number, compound 4's estimate is 1.2-fold (0.08 log units) below it, within the range that was stated.
By their numbers in this assay, from the lowest: compounds 3, 4, 1 and 2 (each within the scatter of the next, the first and the last beyond it).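

Azepan-1-yl in place of diethylamino on a thiocarbonyl carbon gives a step within the scatter in this assay, a 1.5-fold higher number from compound 3 to compound 4 (0.17 log units; within the scatter), so this thioamide position carries a seven-membered ring without a step beyond the scatter. The steps of a 1.3-fold lower number from compound 1 to compound 4 (0.10 log units; within the scatter) and a 1.9-fold lower number from compound 2 to compound 4 (0.27 log units; within the scatter) also stay within the scatter, and thus compound 4, unlike compound 3, does not stand beyond the scatter from compound 2. No measurement on hand accounts for these steps.

Carbonyl and thiocarbonyl never share an amine in these compounds, which leaves the effect of sulfur alone unread; an azepan-1-yl amide with a plain carbonyl would isolate it. Also open, going by these compounds, is how a carboxylic acid in place of the methyl ester on the pyrrolidine, or dimethylamino on the thiocarbonyl carbon, would read.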